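This account rests on a few compounds, and the source may have more. Where it says the series, first, only, none or still open, it means among the compounds named here.

Measured so far:
- compound 1 `COc1ccc(-c2nc3cnccn3c2Nc2cc(OC)c(OC)c(OC)c2)cc1`: 54000 nM
- compound 2 `COc1ccc(Nc2c(-c3ccc(F)cc3)nc3cnccn23)cc1`: 56000 nM

In a functional assay on HEK-293T cells (Homo sapiens) for cytotoxicity, read by MTT assay (on this read-out higher numbers stand for lower toxicity in this test and lower numbers for higher toxicity in this test), compound 1 and compound 2 lie within the usual scatter of each other, so the two numbers give no ranking. Compound 3 `COc1cc(Nc2c(C3C=Nc4ccccc43)nc3cnccn23)cc(OC)c1OC` has not been measured. It keeps the core of compound 1 but loses the 4-methoxyphenyl group on an aromatic carbon of a five-membered aromatic ring, where a group with one five-membered non-aromatic ring and one six-membered aromatic ring of carbon only enters: a group of 9 heavy atoms (8 carbon, 1 nitrogen; one five-membered non-aromatic ring with 1 hetero atom, one six-membered aromatic ring of carbon only) in place of a group of 8 heavy atoms (7 carbon, 1 oxygen; one six-membered aromatic ring of carbon only), on an aromatic carbon.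

Among the compounds with values here, no measured step covers this exchange. Within the data shown here, the only guide is that compound 1 at 54000 nM and compound 2 at 56000 nM sit close together, so a change beyond the scatter is not expected, and the range is kept wide. The expected 1.2-fold lower number from compound 1 to compound 3 (0.08 log units; within the scatter) is estimated to remain within the scatter. For compound 3 the estimated value is 45000 nM, with an expected range of 15000 nM to 120000 nM.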

Compound 3, concentration lethal to 50% of the cells: 12000 nM
Compound 3: the middle estimate sits 3.8-fold (0.57 log units) above what was measured; measured number below the stated range.
By their numbers in this assay, from the lowest: compound 3; then compounds 1 and 2 (each within the scatter of the next).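

In this assay the aromatic carbon of the five-membered aromatic ring proves sensitive to exchange: the group with one five-membered non-aromatic ring and one six-membered aromatic ring of carbon only, in place of 4-methoxyphenyl, gives a 4.5-fold lower number from compound 1 to compound 3 (0.65 log units; beyond the scatter) on this read-out, which means higher toxicity in this test. The leaving and entering groups carry the same counts of hydrogen-bond donors and acceptors and no net charge, so those counts do not separate them. No measurement at hand accounts for the shift.

A single step cannot show whether the non-aromatic ring, the double bond outside aromatic rings or the loss of 4-methoxyphenyl goes with the lower number. On these data alone, how an amine or a carboxylic acid at this carbon would read also stays open.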